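Thiadiazole series: isopropyl to isobutyl on the shared core

This account rests on a few compounds, and the source may have more. Where it says the series, first, only, none or still open, it means among the compounds named here.

Three compounds of the series have been run in an assay on microsomes from liver for inhibition of acyl-CoA desaturase 1 (Rattus norvegicus); on this read-out lower numbers stand for stronger inhibition and higher numbers for weaker inhibition. Compound 1, `CC(C)c1nnc(-c2ccc(N3CCC(Oc4ccccc4C(F)(F)F)CC3)nn2)s1`, gives 8.8 nM in this assay. Compound 3, `Cc1ccccc1OC1CCN(c2ccc(-n3ccnc3)nn2)CC1`, gives 39 nM in this assay, and compound 2, `FC(F)(F)c1ccc(OC2CCN(c3ccc(-n4ccnc4)nn3)CC2)cc1`, gives 371 nM in this assay. Compound 1 therefore holds the lowest number of the three, with its gap to compound 3 and its larger gap to compound 2 both beyond the scatter, so it stands as the most potent inhibitor measured so far. Among the compounds with values here, compounds 2 and 3 differ from compound 1 in more than one place, so no single step between measured compounds can be read from these numbers.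

Compound 4, `CC(C)Cc1nnc(-c2ccc(N3CCC(Oc4ccccc4C(F)(F)F)CC3)nn2)s1`, is the next member and has not yet been measured in this assay. It differs from compound 1 only in one group: isobutyl in place of isopropyl on an aromatic carbon. The change adds one carbon to the chain on the five-membered aromatic ring with 2 nitrogen and 1 sulfur and leaves all other parts of the core untouched.

Within the data shown here, no measured pair shows what this particular exchange does, so the expected step from compound 1 to compound 4 is a 1.4-fold higher number from compound 1 to compound 4 (0.13 log units; within the scatter), which is estimated to lie within the scatter. Compound 4 is expected to give about 12 nM in this assay, with a range from 4 nM to 35 nM.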

Compound 4, half-maximal inhibitory concentration: 37 nM
Compound 4: middle estimate off by 3.1-fold (0.49 log units), on the low side, outside the stated range (above it).
By their numbers in this assay, from the lowest: compound 1; then compounds 4 and 3 (each within the scatter of the next); then compound 2.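

In this assay, replacing isopropyl with isobutyl gives a 4.2-fold higher number from compound 1 to compound 4 (0.62 log units; beyond the scatter), a modest step but one beyond the scatter. This shows that the group on this aromatic carbon of the five-membered aromatic ring with 2 nitrogen and 1 sulfur affects the read-out, even when the change is only from 3 carbon to 4 carbon and no ring, hydrogen-bond donor, hydrogen-bond acceptor or net charge enters or leaves. The earlier compounds could not show this, as neither compound 2 nor compound 3 differs from compound 1 in one place, and nothing on hand accounts for the size or direction of the step.

With only isopropyl and isobutyl shown at this position, it remains open whether the higher number follows the added carbon or the different branching of the chain, which a comparison with methyl, cyclopropyl or a straight butyl chain could help separate. Also open, going by these compounds, is how an amine or a carboxylic acid at this position would read out, and whether the same exchange would give a similar step on a different core.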